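Cyano for chloro on the anilide of compound 1

This account rests on a few compounds, and the source may have more. Where it says the series, first, only, none or still open, it means among the compounds named here.

For the measured compounds named here, compound 1 `COc1ccc(CN(C(=O)Nc2ccc(Cl)cc2)n2cnnc2)cc1OC` is one of two compounds measured in a functional assay on MCF7 cells (Homo sapiens) for cytotoxicity, read by MTT assay, with a stated time of 48 h; a higher number here means a weaker inhibitor, a lower number a stronger inhibitor. In this assay compound 1 reaches only a limit, > 50000 nM, as the limit of > 50000 nM in this assay, at which 1 of the 2 values shown sits, records. Compound 2 `N#Cc1ccc(CN(C(=O)Nc2cc(C(F)(F)F)cc(C(F)(F)F)c2)n2cnnc2)cc1` gives 7220 nM in this assay. Compound 3 `COc1ccc(CN(C(=O)Nc2ccc(C#N)cc2)n2cnnc2)cc1OC` differs from compound 1 by cyano in place of chloro on an aromatic carbon. Going by the values given here, no measured pair carries this change, so the expected step is small, within the scatter and close to the limit: an at least 1.2-fold lower number from compound 1 to compound 3 (0.09 log units; that floor lies within the scatter). Compound 3 is therefore expected to give 40000 nM, in the range 10000 nM to 150000 nM.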

Compound 3, half-maximal inhibitory concentration: > 50000 nM
Compound 3: a limit, no number (the forecaster's own chance of this, stated with the estimate: 55%); at least 1.2-fold (0.09 log units) between middle value and limit.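

Compound 1 and compound 3 both stand at a limit in this assay, so no step can be read between them: the limit of > 50000 nM in this assay, at which 2 of the 3 values shown sit.

As far as these compounds go, whether cyano in place of chloro changes the value in this assay at all remains open.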